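The source may hold more compounds than are shown below. What is called first, only, known or untested is meant among the compounds shown, and "the series" means these compounds.

Compound 2 `COc1c(C(=O)CCC2CCN(CC3CCCCC3)CC2)cc(Cl)c2[nH]ccc12` gives 40.9 nM in an assay for displacement of a labelled ligand from 5-hydroxytryptamine receptor 4 (Homo sapiens), with a stated time of 60 min (on this read-out lower numbers stand for stronger inhibition and higher numbers for weaker inhibition), the lowest of the two numbers recorded, while compound 3 `COc1c(C(=O)CCC2CCN(Cc3ccccc3)CC2)cc(Cl)c2[nH]ccc12` gives 150 nM in this assay; in this assay compound 1 `COc1c(C(=O)CCC2CCN(Cc3ccccc3)CC2)cc(Cl)c2[nH]c([Si](C)(C)C)cc12` gives "not determined" (no result reported). Going by the values given here, the only measured step, a 3.7-fold higher number from compound 2 to compound 3 (0.56 log units; beyond the scatter), concerns the group on the saturated chain carbon bound to the amine nitrogen in a ring, not the aromatic core. Compound 4 `O=C(CCC1CCN(CC2CCCCC2)CC1)c1cc(Cl)c2[nH]ccc2c1` differs from compound 2 by hydrogen in place of methoxy on an aromatic carbon. Among the compounds with values here, no measured step touches this position, so nothing recorded here sets the size of this change. Compound 4 is therefore expected to give about 300 nM, within a range of 60 nM to 1500 nM. This expectation amounts to a step of a 7.3-fold higher number from compound 2 to compound 4 (0.87 log units; beyond the scatter), resting on the structural change alone and carrying wide uncertainty.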

Compound 4, inhibition constant: 37.5 nM
Compound 4: middle estimate off by 8.0-fold (0.90 log units), on the high side; measured number outside the range, below it.
By their numbers in this assay, from the lowest: compounds 4 and 2 (each within the scatter of the next); then compound 3.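

In this assay, hydrogen in place of methoxy on the aromatic carbon para to the chloro group gives a 1.1-fold lower number from compound 2 to compound 4 (0.04 log units; within the scatter) in the series carrying the cyclohexyl group. This first reading at the position shows that, in this pair, the methoxy group can be lost with the two numbers remaining within the scatter. No supporting measurement accounts for this result.

From the compounds shown here alone, whether the same replacement holds with the phenyl group of compound 3 remains open, as does what a hydroxyl or ethoxy group would give at this position.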